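Replacing Nitro with Methyl on an Aromatic Carbon

This account rests on a few compounds, and the source may have more. Where it says the series, first, only, none or still open, it means among the compounds named here.

Measured in a functional assay on MGC-803 cells (Homo sapiens) for inhibition, read by MTT assay, with a stated time of 48 h; a lower number here means a stronger inhibitor, a higher number a weaker inhibitor

Compound 1 `C/C=C/C(=O)N(Cc1ccc(OC)c([N+](=O)[O-])c1)c1cc(OC)c(OC)c(OC)c1` gives 590 nM
Compound 2 `COc1ccc(CNc2cc(OC)c(OC)c(OC)c2)cc1[N+](=O)[O-]` gives 19400 nM
Compound 3 `COc1ccc(CN(C(=O)CO)c2cc(OC)c(OC)c(OC)c2)cc1O` gives 160 nM

Among these three values, compound 1 holds the middle place, with compound 3 lower and compound 2 higher. Compound 4 `C/C=C/C(=O)N(Cc1ccc(OC)c(C)c1)c1cc(OC)c(OC)c(OC)c1` has not yet been measured. It differs from compound 1 by methyl in place of nitro on an aromatic carbon, ortho to a methoxy group.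

For the measured compounds named here, only one measured step links two compounds through a single change, a 33-fold higher number from compound 1 to compound 2 (1.52 log units; beyond the scatter). That step places hydrogen in place of (prop-1-en-1-yl)carbonyl on a nitrogen, so it says nothing directly about the nitro group. Compound 3 also lacks the nitro group and gives 160 nM, but it differs from compound 1 in more than one place. The evidence is therefore thin, and no step beyond the scatter is expected in this assay, with a slight lean towards a lower number. The expected change is a 1.5-fold lower number from compound 1 to compound 4 (0.17 log units; within the scatter). For compound 4 the estimated value is 400 nM, with an expected range from 80 nM to 2000 nM.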

Compound 4, half-maximal inhibitory concentration: 14500 nM
The estimate for compound 4 lay 36-fold (1.56 log units) below the measured number; the whole stated range lies below it.
By their numbers in this assay, from the lowest: compound 3; then compound 1; then compounds 4 and 2 (each within the scatter of the next).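

In this assay the exchange of nitro for methyl gives a 25-fold higher number from compound 1 to compound 4 (1.39 log units; beyond the scatter) and so shows that this aromatic carbon, ortho to a methoxy group, is not indifferent to what it carries. For the compounds shown here, the only earlier single-change step, a 33-fold higher number from compound 1 to compound 2 (1.52 log units; beyond the scatter), concerned the group on the nitrogen, so this is the first direct reading at this position, and it too lies beyond the scatter. Nothing measured here explains the step, and it cannot separate the loss of nitro from the arrival of methyl.

Going by these compounds, whether an amine or a carboxylic acid at this carbon would keep the number close to that of compound 1 remains open. Compound 3 carries a hydroxyl group here but differs from compound 1 in more than one place, so it cannot settle the question.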